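Methyl to Bromo: Estimating an Unmeasured Analogue

The compounds below may be only part of what the source reports. "The series", "measured", "known", "first", "only" and "open" are said of these compounds alone.

Compound 1 `O=C(/C=C/c1ccccc1)Nc1nnc(-c2ccc(Br)cc2)s1` and compound 2 `Cc1ccc(/C=C/C(=O)Nc2nnc(-c3ccc(C)cc3)s2)cc1` share the same core and were both tested in a functional assay on MCF7 cells (Homo sapiens) for antiproliferative activity, read by MTT assay, with a stated time of 48 h; a higher number here means a weaker inhibitor, a lower number a stronger inhibitor. Compound 1 gives 1.5 ug/mL, while compound 2 gives 0.61 ug/mL, the lower of the two numbers and separated from compound 1 by more than the usual scatter. Compound 3 `Cc1ccc(/C=C/C(=O)Nc2nnc(-c3ccc(Br)cc3)s2)cc1` has not yet been measured. It differs from compound 2 by bromo in place of methyl on an aromatic carbon. Going by the values given here, no single step between measured compounds isolates this change. A modest move toward a higher number is expected, roughly a 1.6-fold higher number from compound 2 to compound 3 (0.21 log units; within the scatter). Compound 3 is therefore estimated at 1 ug/mL, with a likely range from 0.4 ug/mL to 2.5 ug/mL.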

Compound 3, half-maximal inhibitory concentration: 1.32 ug/mL
Beside the measured number, compound 3's estimate is 1.3-fold (0.12 log units) below it, and the stated range covers the measured number.
By their numbers in this assay, from the lowest: compound 2; then compounds 3 and 1 (each within the scatter of the next).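

In this assay, bromo in place of methyl, on an aromatic carbon para to a large group, gives a 2.2-fold higher number from compound 2 to compound 3 (0.34 log units; beyond the scatter), so 4-methylphenyl to 4-bromophenyl is now read directly and this position responds to the change. By contrast, methyl in place of hydrogen at the other changed place gives a 1.1-fold lower number from compound 1 to compound 3 (0.06 log units; within the scatter), which lies within the scatter. No measurement here explains the size of either step.

Still open, going by these compounds, is where other groups at the para position, such as an amine or a methoxy group, would fall relative to methyl and bromo.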